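Chloro to Amino on the Core: Compound 1 to Compound 3

A few compounds are considered here, and "the series" means these few. Any claim that something is new, unique, unknown or untested is made for them only; others in the source may bear on it.

Measured compounds:
compound 1 `ClCc1ccccc1Cn1cnc2c(Cl)nc(Cl)nc21`, 630 nM
compound 2 `ClCc1cccc(Cn2cnc3c(Cl)ncnc32)c1`, 37200 nM

In a functional assay on MOLT-4 cells (Homo sapiens) for cytotoxicity, read by sulforhodamine B assay, with a stated time of 48 h (a higher number here means a weaker inhibitor of growth, a lower number a stronger inhibitor of growth), compound 1 gives 630 nM, the lowest of the two numbers recorded, and compound 2 gives 37200 nM, a number that lies beyond the scatter above that of compound 1. For the measured compounds named here, compound 2 differs from compound 1 in more than one place, so no single step between the two is counted here; their two values are all that can be said of the pair.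

Compound 3 `Nc1nc(Cl)c2ncn(Cc3ccccc3CCl)c2n1` has not yet been measured. It differs from compound 1 in one place: amino in place of chloro on an aromatic carbon. Going by the values given here, no counted step in this assay is available for such a change, so the expectation rests on compound 1 alone, whose value of 630 nM is the starting point. The size of the change is small in atoms, and the expected step is a 2.4-fold higher number from compound 1 to compound 3 (0.38 log units; beyond the scatter), a modest shift, most likely towards a higher number, though a result within the scatter is possible. Compound 3 is therefore estimated at 1500 nM, with a range from 400 nM to 6000 nM.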

Compound 3, concentration for total growth inhibition: > 100000 nM
Compound 3 ended at the assay's limit (the forecaster's own chance of this, stated with the estimate: 5%); middle value at least 66-fold (1.82 log units) from the limit.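

Compound 1 and compound 2 differ in more than one place, so only now can a single change at this position be read: amino in place of chloro on the aromatic carbon between two ring nitrogen atoms gives an at least 150-fold higher number from compound 1 to compound 3 (2.20 log units; beyond the scatter). In this assay, as far as these compounds go, compound 3 gives > 100000 nM, which is a limit of the assay and not a number, so the full size of the step stays unknown. The step still shows that this exchange of one heavy atom, with the rest of compound 1 unchanged, is enough to carry the result to the end of the assay's range: the limit of > 100000 nM in this assay, at which 1 of the 3 values shown sits.

The compounds shown do not tell whether this outcome belongs to amino in particular or would follow any replacement of chloro at this carbon, a question that a fluoro, a methoxy or a methylamino group there would address. They also leave open whether the same exchange would read alike on a compound with the chloromethyl group placed as in compound 2.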